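The compounds below may be only part of what the source reports. "The series", "measured", "known", "first", "only" and "open" are said of these compounds alone.

Compound 1 `O=C(N/N=C/c1cc(I)cc(I)c1O)c1ccccc1` gives > 50000 nM in a functional assay on HepG2 cells (Homo sapiens) for cytotoxicity, with a stated time of 24 h; on this read-out lower numbers stand for stronger inhibition and higher numbers for weaker inhibition.
Compound 2 `O=C(N/N=C/c1cc(I)cc(I)c1O)c1ccc(C(F)(F)F)cc1` gives 11700 nM in this assay.
Compound 3 `Cc1ccc(C(=O)N/N=C/c2cc(I)c(O)c(I)c2)cc1` gives > 100000 nM in this assay.

Of the three measured compounds, only compound 2 returns a number in this assay. The value of compound 1 is a limit of the assay (the limit of > 50000 nM in this assay, at which 1 of the 3 values shown sits). The value of compound 3 is likewise a limit (the limit of > 100000 nM in this assay, at which 1 of the 3 values shown sits), so compound 3 stands at the weak end of what has been measured, with no number of its own to compare against.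

Compound 4 `O=C(N/N=C/c1cc(I)c(O)c(I)c1)c1ccc(I)cc1` differs from compound 3 by iodo in place of methyl on an aromatic carbon. Going by the values given here, the one measured step, an at least 4.2-fold lower number from compound 1 to compound 2 (0.63 log units; beyond the scatter), concerns a different exchange on an aromatic carbon and starts from a limit, so only its lower bound is known. Among the compounds with values here, no measured step exchanges methyl for iodo, so none bears directly on the change from compound 3 to compound 4. With nothing to argue for a move in either direction, compound 4 is expected to remain weak, and the step is estimated as an at least 1.6-fold lower number from compound 3 to compound 4 (0.22 log units; that floor lies within the scatter). The expected value for compound 4 in this assay is 60000 nM, with a range from 15000 nM to 200000 nM, and it is about as likely as not that the assay again reports only a limit for compound 4.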

Compound 4, half-maximal inhibitory concentration: > 50000 nM
Compound 4 was reported as a limit (the forecaster's own chance of this, stated with the estimate: 55%); the middle value lies beyond the limit too.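

Compound 3 gives > 100000 nM in this assay, and this is a limit. Compound 4 gives > 50000 nM, which is also a limit, so the step from compound 3 to compound 4 cannot be read. The compounds shown leave open whether iodo in place of methyl on an aromatic carbon changes the read-out in this assay at all, and by how much.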